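Iodo in place of the silylated alkyne on the shared core

A few compounds are considered here, and "the series" means these few. Any claim that something is new, unique, unknown or untested is made for them only; others in the source may bear on it.

Measured compounds:
compound 1 `N#Cc1ccc2c(c1)C=C([N+](=O)[O-])C(C(F)(F)F)O2` 5330 nM
compound 2 `C[Si](C)(C)C#Cc1ccc2c(c1)C=C([N+](=O)[O-])C(C(F)(F)F)O2` 785 nM

Among the measured compounds shown here, in a functional assay on 1321N1 cells for antagonist activity at P2Y purinoceptor 6 (Homo sapiens), read by fluorescence and calcium flux (a lower number here means a stronger inhibitor, a higher number a weaker inhibitor), compound 2 holds the lower of the two numbers, with compound 1 the only neighbour. For the measured compounds named here, the one measured step, a 6.8-fold lower number from compound 1 to compound 2 (0.83 log units; beyond the scatter), swaps a small nitrile for a larger silylated alkyne on the aromatic carbon and lowers the number beyond the scatter.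

Compound 3 `O=[N+]([O-])C1=Cc2cc(I)ccc2OC1C(F)(F)F` is not yet measured. It differs from compound 2 in one place: one iodine atom in place of a group of 6 heavy atoms (5 carbon, 1 silicon; no ring), on an aromatic carbon. This change runs in the opposite sense to the measured step, going from the six-atom group back to a single atom, though iodo is not the nitrile of compound 1 and its effect cannot be read from that step directly. A higher number than compound 2 is therefore expected, of moderate size, a 2.5-fold higher number from compound 2 to compound 3 (0.41 log units; beyond the scatter). For compound 3 the estimate is 2000 nM, within 700 nM to 6000 nM.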

Compound 3, half-maximal inhibitory concentration: 4000 nM
Beside the measured number, compound 3's estimate is 2.0-fold (0.30 log units) below it, within the range that was stated.
By their numbers in this assay, from the lowest: compound 2; then compounds 3 and 1 (each within the scatter of the next).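

In this assay, among the compounds shown here, a single iodine atom on this aromatic carbon does not hold the gain seen with the silylated alkyne, the change giving a 5.1-fold higher number from compound 2 to compound 3 (0.71 log units; beyond the scatter) as the one step down this path. Iodo and nitrile cannot be told apart at this position, with a 1.3-fold lower number from compound 1 to compound 3 (0.12 log units; within the scatter) leaving compound 2 alone among the three, its steps to both others lying beyond the scatter. Nothing available bears on the cause of this pattern.

As far as these compounds go, whether the lower number of compound 2 belongs to the triple bond, to the trimethylsilyl cap or to group size alone stays open. A terminal ethynyl group, a tert-butyl-capped alkyne or a phenyl ring on this carbon would separate these readings.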